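This account rests on a few compounds, and the source may have more. Where it says the series, first, only, none or still open, it means among the compounds named here.

Of the compounds shown here, three that share one core have been measured in a functional assay (muscle tissue) with Cavia porcellus as the target; a lower number here means that less compound is needed, a higher number that more compound is needed for the effect. Compound 1 `COC(=O)C1=C(C)N=C(C)/C(=C(\O)OC)C1c1ccc(Cl)cc1`, with a 4-chlorophenyl group, gives 8130 nM. Compound 2 `COC(=O)C1=C(C)N=C(C)/C(=C(\O)OC)C1c1ccccc1Cl`, with a 2-chlorophenyl group, gives 2.19 nM. Compound 3 `COC(=O)C1=C(C)N=C(C)/C(=C(\O)OC)C1c1ccccc1OC`, with a 2-methoxyphenyl group, gives 57.5 nM, which places it in the middle of the three.

Compound 4 `COC(=O)C1=C(C)N=C(C)/C(=C(\O)OC)C1c1cccc(C)c1` differs from compound 3 in one place, with 3-methylphenyl in place of 2-methoxyphenyl on a saturated ring carbon. Among the measured compounds shown here, no measured compound carries a 3-methylphenyl group, so no measured step matches this change directly.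

Three large steps offer indirect guidance. Changing the aromatic group gave a 3700-fold lower number from compound 1 to compound 2 (3.57 log units; beyond the scatter) and also a 140-fold lower number from compound 1 to compound 3 (2.15 log units; beyond the scatter), while methoxy in place of chloro gave a 26-fold higher number from compound 2 to compound 3 (1.42 log units; beyond the scatter). These steps show that the number in this assay can shift strongly with this group. Both 2-substituted groups gave far lower numbers than compound 1 at 8130 nM, so compound 4 is expected to fall between compound 3 and compound 1, probably nearer compound 3.

A moderate rise is therefore expected, and the estimated change is a 3.5-fold higher number from compound 3 to compound 4 (0.54 log units; beyond the scatter). For compound 4 the expected value is 200 nM, with an estimated range from 30 nM to 1500 nM.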

Compound 4, half-maximal effective concentration: 110 nM
Beside the measured number, compound 4's estimate is 1.8-fold (0.26 log units) above it; low and high end bracket the measured number.
By their numbers in this assay, from the lowest: compound 2; then compounds 3 and 4 (each within the scatter of the next); then compound 1.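

In this assay, the switch to the 3-methylphenyl group gives a 1.9-fold higher number from compound 3 to compound 4 (0.28 log units; within the scatter) and so leaves the two compounds indistinguishable, even though 3-methylphenyl carries no hydrogen-bond acceptor and 2-methoxyphenyl carries one. The 2-chlorophenyl and 2-methoxyphenyl groups are also no longer the only ones far from the 4-chlorophenyl group: the data show a 74-fold lower number from compound 1 to compound 4 (1.87 log units; beyond the scatter) in this assay, while the comparison with the best compound shows a 50-fold higher number from compound 2 to compound 4 (1.70 log units; beyond the scatter) and thus a clear gap that remains. No independent evidence is available to explain any of these differences.

The four compounds leave open how much of each difference comes from the kind of substituent and how much from where it sits on the phenyl ring, since only chloro appears in more than one place, while methyl and methoxy each appear in just one. They also leave open where an unsubstituted phenyl group would fall, and whether a phenyl ring carrying a nitro group or an amine would follow the same trend.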